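The source may hold more compounds than are shown below. What is called first, only, known or untested is meant among the compounds shown, and "the series" means these compounds.

Measured so far:
compound 1 `O=C(O)CCC/C=C\C[C@H]1[C@H](F)CC[C@@H]1NS(=O)(=O)c1ccccc1[N+](=O)[O-]` — 1800 nM
compound 2 `O=C(O)CC/C=C\C[C@H]1[C@H](F)CC[C@@H]1NS(=O)(=O)c1ccc(Cl)cc1` — 210 nM

Going by the values given here, in a functional assay on a cell-free system (plasma) for inhibition of thromboxane A2 receptor (Homo sapiens), read by turbidimetry (a lower number here means a stronger inhibitor, a higher number a weaker inhibitor), compound 2 gives 210 nM, the lowest of the two numbers on hand; compound 1, the only neighbour, gives 1800 nM, a gap beyond the usual scatter. Compounds 1 and 2 differ in two places at once, so no single step can be read from that pair.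

Compound 3 `O=C(O)CC/C=C\C[C@H]1[C@H](F)CC[C@@H]1NS(=O)(=O)c1ccccc1[N+](=O)[O-]` is not yet measured. Relative to compound 2 the change is 2-nitrophenyl in place of 4-chlorophenyl on a sulfonyl sulfur. Compound 3 shares the nitro-bearing aryl sulfonamide with compound 1 and the shorter acid chain with compound 2, so both measured values frame it, and nothing in the data separates the contribution of each part.

The step of a 4.3-fold higher number from compound 2 to compound 3 (0.63 log units; beyond the scatter) is expected to run toward a higher number, beyond the scatter. For compound 3 an estimate of 900 nM is made, within 250 nM to 3500 nM.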

Compound 3, half-maximal inhibitory concentration: 560 nM
The estimate for compound 3 lay 1.6-fold (0.21 log units) above the measured number, within the range that was stated.
By their numbers in this assay, from the lowest: compound 2; then compound 3; then compound 1.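

In this assay, the group on the sulfonyl sulfur can now be read alone: 2-nitrophenyl in place of 4-chlorophenyl gives a 2.7-fold higher number from compound 2 to compound 3 (0.43 log units; beyond the scatter). The acid chain can also be read alone with 2-nitrophenyl held fixed: carboxy in place of carboxymethyl gives a 3.2-fold lower number from compound 1 to compound 3 (0.51 log units; beyond the scatter), so the gap between compound 1 and compound 2 divides into two steps, each beyond the scatter and each running toward compound 2. Nothing on hand gives a reason for either step.

Going by these compounds alone, whether the chain step keeps its direction and size with 4-chlorophenyl on the sulfonyl sulfur remains open, as the series holds only one pair for that change. Also open, going by these compounds, is how a plain phenyl or a thiophene would compare at this place on the sulfonyl sulfur.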